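Bromo for ethyl on the aryl ring of compound 2

The source may report more compounds than this note shows. Statements on the series, on what has been measured and on what is new or still open speak of the compounds shown alone.

Measured so far:
compound 1, `CS(=O)(=O)c1ccc(N2N=C(c3ccccc3)CCC2=O)cc1`, 47.3%
compound 2, `CCc1ccc(C2=NN(c3ccc(S(C)(=O)=O)cc3)C(=O)CC2)cc1`, 65.7%

Both compounds were tested in a functional assay on the whole organism (strain Wistar) for inhibition, with Rattus norvegicus as the target, read by paw edema, with stated times of 30 min and 5 h, at a dose of 0.05 mmol/kg by the oral route; a lower number here means less inhibition, a higher number more inhibition at the dose given (going by the name of the read-out). Compound 1, `CS(=O)(=O)c1ccc(N2N=C(c3ccccc3)CCC2=O)cc1`, gives 47.3%, and compound 2, `CCc1ccc(C2=NN(c3ccc(S(C)(=O)=O)cc3)C(=O)CC2)cc1`, gives 65.7%. The single step between them, ethyl in place of hydrogen on an aromatic carbon, reads a number 18.4 percentage points higher from compound 1 to compound 2 (beyond the scatter), so compound 2 stands highest of the two numbers shown, with compound 1 the only neighbour.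

Compound 3, `CS(=O)(=O)c1ccc(N2N=C(c3ccc(Br)cc3)CCC2=O)cc1`, has not yet been measured. Its change from compound 2 is bromo in place of ethyl on an aromatic carbon. Among the measured compounds shown here, only the step from compound 1 to compound 2 bears on this, and it concerns a different substituent at the same place; it shows that an ethyl group there raised the read-out modestly, while nothing shows what bromo does. The expected step in this assay for compound 3 is therefore a small loss or none beyond the scatter, a number 7.7 percentage points lower from compound 2 to compound 3 (within the scatter). For compound 3 the estimated read-out is 58%, expected to lie between 40% and 75%.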

Compound 3, a percentage reported as inhibition, in the whole organism at one dose (the size of the read-out at that dose, not a potency): 31.5%
For compound 3 the middle estimate is 26.5 percentage points above the measured one, and the stated range ends above it.
By their numbers in this assay, from the lowest: compound 3; then compound 1; then compound 2.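

Substitution at this place on the aromatic ring does not raise the read-out in itself: in this assay ethyl gave a number 18.4 percentage points higher from compound 1 to compound 2 (beyond the scatter), whereas bromo gives a number 15.8 percentage points lower from compound 1 to compound 3 (beyond the scatter), so the direction of the step depends on the group that enters. Exchanging one substituent for the other at the same place gives a number 34.2 percentage points lower from compound 2 to compound 3 (beyond the scatter), the widest step among the three compounds, which shows that the read-out in this assay responds strongly to what stands on this ring and that the gain seen with ethyl does not carry over to bromo. Nothing available here accounts for the two groups moving the read-out in opposite directions.

From the compounds shown here alone, it remains open whether a longer chain such as propyl would keep or extend the higher number seen with ethyl, and whether a lighter halogen such as chloro or fluoro at the same place would fall with bromo. The compounds shown also leave open how a methoxy group or an amine would read there, and whether the same order would hold at another dose.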